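The source may report more compounds than this note shows. Statements on the series, on what has been measured and on what is new or still open speak of the compounds shown alone.

Measured compounds:
Compound 1 `Cc1cc(Oc2ccnc3c([N+](=O)[O-])cccc23)ccc1NC(=O)c1cc(C(F)(F)F)cc(C(F)(F)F)c1`: in a functional assay on PLC-PRF-5 cells (Homo sapiens) for inhibition (a lower number here means a stronger inhibitor, a higher number a weaker inhibitor), compound 1 gives > 40000 nM, a limit of the assay rather than a number.
Compound 2 `Cc1cc(Oc2ccnc3c(N)cccc23)ccc1NC(=O)c1cc(C(F)(F)F)cc(C(F)(F)F)c1`: in this assay compound 2 gives 25400 nM.

Among the measured compounds shown here, compound 2 thus holds the only actual number; the other value is a limit. For the measured compounds named here, the single measured step, an at least 1.5-fold lower number from compound 1 to compound 2 (0.19 log units; that floor lies within the scatter), has its floor set by the limit of > 40000 nM in this assay, at which 1 of the 2 values shown sits. Compound 3 `CC(=O)Nc1cccc2c(Oc3ccc(NC(=O)c4cc(C(F)(F)F)cc(C(F)(F)F)c4)c(C)c3)ccnc12` differs from compound 2 by acetyl in place of hydrogen on a nitrogen on an aromatic ring. Going by the values given here, no measured step covers such a change, so no move beyond the scatter is expected, with only a faint lean toward a higher number. Compound 3 is expected to give 30000 nM, in the range 9000 nM to 90000 nM. That expectation amounts to a 1.2-fold higher number from compound 2 to compound 3 (0.07 log units; within the scatter).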

Compound 3, half-maximal inhibitory concentration: > 40000 nM
Compound 3 gave a limit, no number; the forecaster's own chance of this, stated with the estimate: 35%; middle value at least 1.3-fold (0.12 log units) away from the limit.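

Acetyl in place of hydrogen on the nitrogen brings an at least 1.5-fold higher number from compound 2 to compound 3 (0.19 log units; that floor lies within the scatter), so acetamido shows no stronger inhibition than amino in this assay. Going by these compounds, the value of compound 3 is a limit and not a number, so the true size of this step stays unknown, and the steps that end on two limits cannot be read. Most of the compounds at this position now sit at the same ceiling: the limit of > 40000 nM in this assay, at which 2 of the 3 values shown sit.

Open, on these data alone, is what a methyl group on this nitrogen, or a carboxylic acid on this aromatic carbon, would do. Also open, as far as these compounds go, is whether any group here gives a clearly lower number than amino.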